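Replacing 6-methoxypyridin-3-yl in compound 2

A few compounds are considered here, and "the series" means these few. Any claim that something is new, unique, unknown or untested is made for them only; others in the source may bear on it.

Compound 1 `COc1ccc(-c2nc3cnccc3n2-c2cc(OC)c(OC)c(OC)c2)cc1O` reads > 20000 nM in a functional assay on A549 cells (Homo sapiens) for antiproliferative activity, read by MTT assay, with a stated time of 48 h (a lower number here means a stronger inhibitor, a higher number a weaker inhibitor), and that figure is a limit of the assay, not a number. For the measured compounds named here, compound 2 `COc1ccc(-c2cc3c(cn2)[nH]c(=O)n3-c2cc(OC)c(OC)c(OC)c2)cn1` gives 1220 nM in this assay and so holds the only actual number among the compounds measured so far. Going by the values given here, no step between measured compounds is available to calibrate what follows.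

Compound 3 `COc1ccc(-c2cc3c(cn2)[nH]c(=O)n3-c2cc(OC)c(OC)c(OC)c2)cc1N` is still to be measured. It carries 3-amino-4-methoxyphenyl in place of 6-methoxypyridin-3-yl on an aromatic carbon while the rest of compound 2 stays unchanged. With so little to go on, the expectation in this assay is a step beyond the scatter, toward stronger inhibition, held with wide uncertainty. The estimated change is an 8.1-fold lower number from compound 2 to compound 3 (0.91 log units; beyond the scatter) toward stronger inhibition. For compound 3 the expected value is 150 nM within an estimated range of 20 nM to 1000 nM in this read-out.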

Compound 3, half-maximal inhibitory concentration: 1140 nM
The estimate for compound 3 lay 7.6-fold (0.88 log units) below the measured number; measured number above the stated range.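

This position, on an aromatic carbon next to the ring nitrogen, now has its first readable step in this assay: exchanging 6-methoxypyridin-3-yl for 3-amino-4-methoxyphenyl gives a 1.1-fold lower number from compound 2 to compound 3 (0.03 log units; within the scatter). The two aryl groups differ in ring make-up and in hydrogen-bond donors, one having a ring nitrogen and no donor and the other being of carbon only and carrying an amino group, yet compound 2 and compound 3 stand level in this read-out. Nothing measured here gives a cause for this result.

As far as these compounds go, this exchange alters the ring and the amino group together, so the contribution of each stays open; a plain 4-methoxyphenyl at this place would separate them. From the compounds shown here alone, whether a carboxylic acid or a morpholine on this ring would move the number also remains open.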